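A few compounds are considered here, and "the series" means these few. Any claim that something is new, unique, unknown or untested is made for them only; others in the source may bear on it.

Measured compounds:
compound 1, `CN(c1ccccc1)S(=O)(=O)c1ccc(NC(=O)c2ccc(Cl)cc2Cl)cc1` — 50%
compound 3, `O=C(Nc1ccc(S(=O)(=O)Nc2ccccc2)cc1)c1ccc(Cl)cc1F` — 57%
compound 2, `O=C(Nc1ccc(S(=O)(=O)Nc2ncccn2)cc1)c1ccc(Cl)cc1Cl` — "not determined" (no result reported)

In a functional assay on HEK293 cells for agonist activity at probable G-protein coupled receptor 27 (Homo sapiens), read by a luciferase reporter and beta-arrestin recruitment, with a stated time of 10 min (on this read-out lower numbers stand for smaller maximal responses and higher numbers for larger maximal responses), compound 1 gives 50%, the lowest of the two numbers reported. Its nearest neighbour is compound 3, whose value of 57% lies within the usual scatter of compound 1, so the two cannot be ordered against each other. Compound 2 has no reported number in this assay.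

Compound 4, `O=C(Nc1ccc(S(=O)(=O)Nc2ccccc2)cc1)c1ccc(Cl)cc1Cl`, is not yet measured. Relative to compound 1 it differs in one place: hydrogen in place of methyl on a sulfonamide nitrogen. For the measured compounds named here, no pair of measured compounds shows this change on its own, so there is no measured step to lean on. Among the measured compounds, compound 3 also carries a hydrogen on its sulfonamide nitrogen and reaches 57%, which sits close to compound 1. On that basis the step from compound 1 to compound 4 is expected to be small, a number 4 percentage points higher from compound 1 to compound 4 (within the scatter), with no direction beyond the scatter. Compound 4 is therefore estimated to reach 54%, in a range from 40% to 68%.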

Compound 4, largest response reached (Emax), in percent of the reference or control that the assay uses: 100%
Beside the measured number, compound 4's estimate is 46 percentage points below it; the measured number lies above the stated range.
By their numbers in this assay, from the lowest: compounds 1 and 3 (each within the scatter of the next); then compound 4.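

In this assay, the sulfonamide nitrogen proves to be a sensitive position: hydrogen in place of methyl there gives a number 50 percentage points higher from compound 1 to compound 4 (beyond the scatter) and so separates two compounds by far more than the scatter. The same compound also shows that the aromatic carbon carrying chloro or fluoro matters, with chloro in place of fluoro giving a number 43 percentage points higher from compound 3 to compound 4 (beyond the scatter), which could not be seen from compound 1 and compound 3, as they differ in more than one place. Nothing shown here accounts for either step.

From the compounds shown here alone, it remains open whether an ethyl group on the sulfonamide nitrogen would behave like methyl or like hydrogen. Going by these compounds, it is equally open whether bromo or methoxy in place of that chloro would keep the response of compound 4.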